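The source may report more compounds than this note shows. Statements on the series, on what has been measured and on what is new or still open speak of the compounds shown alone.

Working notes on the series. Compound 1 `O=C1NCCN(c2ccccn2)N1` is the unsubstituted parent; in a functional assay on cells for inhibition of Polyunsaturated fatty acid 5-lipoxygenase (Homo sapiens) (on this read-out higher numbers stand for weaker inhibition and lower numbers for stronger inhibition), compound 1 gives 8600 nM. Compound 2 `O=C1NCCN(c2cccc(Br)n2)N1` carries bromo on an aromatic carbon, and in this assay compound 2 gives 4600 nM, the change being a 1.9-fold lower number from compound 1 to compound 2 (0.27 log units; within the scatter). Compound 3 `COc1cccc(N2CCNC(=O)N2)n1` carries methoxy at the same place; in this assay compound 3 gives 3500 nM. The step of a 2.5-fold lower number from compound 1 to compound 3 (0.39 log units; beyond the scatter) is the only one of the three that clears the scatter, whereas a 1.3-fold lower number from compound 2 to compound 3 (0.12 log units; within the scatter) does not. Compound 3 thus holds the lowest of the three numbers, but its gap to compound 2 lies within the scatter, so no order between those two can be claimed.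

Compound 4 `O=C1NCCN(c2cccc(-c3ccccn3)n2)N1` is the next step from compound 3: pyridin-2-yl in place of methoxy on an aromatic carbon. The measured steps that touch this position are a 2.5-fold lower number from compound 1 to compound 3 (0.39 log units; beyond the scatter) and a 1.3-fold lower number from compound 2 to compound 3 (0.12 log units; within the scatter), both modest or within the scatter. Within the data shown here, no measured step brings a ring into this position, so the direction of the change is not supported by the data beyond the scatter. Compound 4 is expected to give about 3000 nM in this assay, with a range from 1000 nM to 9000 nM. The expected step of a 1.2-fold lower number from compound 3 to compound 4 (0.07 log units; within the scatter) is therefore taken as small, with the uncertainty widened for the untested ring.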

Compound 4, half-maximal inhibitory concentration: > 50000 nM
Compound 4: a limit, no number; the forecaster's own chance of this, stated with the estimate: 5%; middle value at least 16-fold (1.22 log units) away from the limit.
By their numbers in this assay, from the lowest: compounds 3, 2 and 1 (each within the scatter of the next, the first and the last beyond it). At a limit, above all of these: compound 4.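

Compound 4 gives a limit and not a number: the limit of > 50000 nM in this assay, at which 1 of the 4 values shown sits.

Hydrogen, bromo and methoxy on this aromatic carbon, next to the ring nitrogen, gave steps that were modest or within the scatter, whereas pyridin-2-yl gives an at least 14-fold higher number from compound 3 to compound 4 (1.15 log units; beyond the scatter), an at least 10-fold higher number from compound 2 to compound 4 (1.03 log units; beyond the scatter) and an at least 5.8-fold higher number from compound 1 to compound 4 (0.76 log units; beyond the scatter). Among these compounds, the position therefore does not accept every group alike: in this assay the first ring placed here is also the first group to give a large step, and it moves the number upward, against the direction of the steps to bromo and methoxy, of which only the step to methoxy clears the scatter.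

As far as these compounds go, whether the rise belongs to the ring as such, to the number of heavy atoms or to the nitrogen of the entering ring stays open, since pyridin-2-yl differs from methoxy in all three. A phenyl ring, a pyridin-4-yl ring, an ethyl chain or a dimethylamino group at the same place would begin to separate these readings.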